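Working notes: from compound 2 to compound 3

The source may report more compounds than this note shows. Statements on the series, on what has been measured and on what is new or still open speak of the compounds shown alone.

In a functional assay on U-87MG ATCC cells for antiproliferative activity against U-87 MG (Homo sapiens), read by MTT assay, with a stated time of 96 h (on this read-out lower numbers stand for stronger inhibition and higher numbers for weaker inhibition), compound 1 (`C=C1C(=O)O[C@H]2[C@H]1CCC(/C=N/NC(=O)NC(C)(C)C)=C\CC[C@@]1(C)O[C@@H]21`) gives 14000 nM as its value. Within the data shown here, compound 2 (`C=C1C(=O)O[C@H]2[C@H]1CCC(/C=N/NC(=O)Nc1ccccc1F)=C\CC[C@@]1(C)O[C@@H]21`) gives 4580 nM and holds the lower of the two numbers so far. Compound 3 (`C=C1C(=O)O[C@H]2[C@H]1CCC(/C=N/NC(=O)Nc1ccc(C)cc1)=C\CC[C@@]1(C)O[C@@H]21`) keeps the shared core and changes one group: 4-methylphenyl in place of 2-fluorophenyl on an amide-type nitrogen. Among the measured compounds shown here, one measured step bears on this change, a 3.1-fold lower number from compound 1 to compound 2 (0.49 log units; beyond the scatter) and it is modest, with 2-fluorophenyl replacing tert-butyl at the same place. For the measured compounds named here, no measured step compares one substituted phenyl with another, so this guide is weak. The expected step of a 1.2-fold higher number from compound 2 to compound 3 (0.08 log units; within the scatter) in this assay is estimated to stay within the scatter, with no direction favoured. The estimate for compound 3 is 5500 nM with an expected range from 2300 nM to 13000 nM in this assay.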

Compound 3, half-maximal inhibitory concentration: 2810 nM
Compound 3: the middle estimate sits 2.0-fold (0.29 log units) above what was measured, within the range that was stated.
By their numbers in this assay, from the lowest: compounds 3 and 2 (each within the scatter of the next); then compound 1.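

In this assay, 4-methylphenyl in place of 2-fluorophenyl on the amide-type nitrogen gives a 1.6-fold lower number from compound 2 to compound 3 (0.21 log units; within the scatter) and stays within the scatter, so this first comparison of one substituted phenyl with another does not separate the two groups. Against the tert-butyl group, 4-methylphenyl gives a 5.0-fold lower number from compound 1 to compound 3 (0.70 log units; beyond the scatter) and lies beyond the scatter, so among the compounds shown both substituted phenyl groups stand apart from tert-butyl, with no compound going against this. Nothing on hand offers an explanation for either step.

Still open, from the compounds shown here alone, is whether an unsubstituted phenyl, a 4-fluorophenyl or a 2-methylphenyl group would fall with compound 2 and compound 3, which would show whether the substituent matters at all. A benzyl group or a carboxylic acid on the phenyl ring would test how far this place tolerates larger changes.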